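The source may report more compounds than this note shows. Statements on the series, on what has been measured and on what is new or still open speak of the compounds shown alone.

Measured compounds in a functional assay on CCRF-CEM cells (Homo sapiens) for inhibition; on this read-out lower numbers stand for stronger inhibition and higher numbers for weaker inhibition:
- compound 1 `CC(=O)OC(C)n1cnc2c(Cl)nc(I)nc21`: 15900 nM
- compound 2 `CC(O)n1cnc2c(Cl)nc(I)nc21`: > 500000 nM
- compound 3 `CC(=O)OC(C)n1cnc2c(S)nc(F)nc21`: > 500000 nM

Compound 2 sits at a limit of this assay, so for compound 2 only that limit is known. The change from compound 1 to compound 2 is hydrogen in place of acetyl on an oxygen on a saturated carbon and it gave an at least 31-fold higher number from compound 1 to compound 2 (1.49 log units; beyond the scatter).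

Compound 3 also sits at a limit of this assay, so for compound 3 no number is known. The difference between the core of compound 1 and the core of compound 3 is not broken down here.

Compound 4 `CC(O)n1cnc2c(S)nc(F)nc21` is not yet measured. Within the data shown here, it differs from compound 3 by hydrogen in place of acetyl on an oxygen on a saturated carbon, which is the same change as the one from compound 1 to compound 2. The expected step is a step that the limit leaves unreadable from compound 3 to compound 4; this rests on the earlier step of an at least 31-fold higher number from compound 1 to compound 2 (1.49 log units; beyond the scatter), which weakened inhibition, and on (the limit of > 500000 nM in this assay, at which 2 of the 3 values shown sit), at which compound 3 already sits. In this assay compound 4 is therefore expected to give about 3000000 nM, most likely reported only as a limit, with an expected range from 500000 nM to 20000000 nM.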

Compound 4, half-maximal inhibitory concentration: > 500000 nM
Compound 4 ended at the assay's limit (the forecaster's own chance of this, stated with the estimate: 90%); the middle value lies beyond the limit too.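

No step can be read from compound 3 to compound 4 in this assay, because both compounds give only a limit and not a number: the limit of > 500000 nM in this assay, at which 3 of the 4 values shown sit.

The compounds shown leave open how much the change from acetoxy to hydroxy matters on the core of compound 3, and whether either compound inhibits measurably at all.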